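A few compounds are considered here, and "the series" means these few. Any claim that something is new, unique, unknown or untested is made for them only; others in the source may bear on it.

Compound 1, `CCCCCCCCNC(=N)NC(=N)Nc1ccccc1`, gives 4.43 in a physicochemical assay for lipophilicity, in phosphate buffer, measured as octanol-water partition, at pH 11.5; on this read-out lower numbers stand for lower lipophilicity and higher numbers for higher lipophilicity. Compound 2, `CCCCCCCCNC(=N)NC(=N)Nc1ccc(OC)cc1`, gives 4.41 in this assay.

In this assay compound 2 holds the lower of the two numbers, though its gap to compound 1 lies within the scatter. Compound 3, `CCCCCCCCNC(=N)NC(=N)Nc1ccc(C(F)(F)F)cc1`, differs from compound 2 in one place: trifluoromethyl in place of methoxy on an aromatic carbon. For the measured compounds named here, the only measured step, a number 0.02 log units lower from compound 1 to compound 2 (within the scatter), concerns methoxy entering in place of hydrogen and gives no direct guide to trifluoromethyl; no measured pair shows trifluoromethyl entering. Compound 3 is nonetheless expected to come out higher, by a step of a number 0.79 log units higher from compound 2 to compound 3 (beyond the scatter). The estimate for compound 3 is 5.2, with a range from 4.7 to 5.7.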

Compound 3, partition coefficient: 5.31
Compound 3: the middle estimate sits 0.11 log units below what was measured, within the range that was stated.
By their numbers in this assay, from the lowest: compounds 2 and 1 (each within the scatter of the next); then compound 3.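

In this assay this position proved able to shift the read-out: trifluoromethyl in place of methoxy gives a number 0.90 log units higher from compound 2 to compound 3 (beyond the scatter) and trifluoromethyl in place of hydrogen gives a number 0.88 log units higher from compound 1 to compound 3 (beyond the scatter) while methoxy in place of hydrogen had stayed within the scatter. The group placed on this aromatic carbon therefore matters, at least for these compounds. Nothing available speaks to the reason for this rise.

As far as these compounds go, whether an amine, a carboxylic acid or a nitrile at this place would move the number remains open. So does whether trifluoromethyl would give a step of similar size with a shorter chain on the shared core.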